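The source may report more compounds than this note shows. Statements on the series, on what has been measured and on what is new or still open speak of the compounds shown alone.

Working notes on the series of two measured compounds sharing one core. Compound 1 `COc1ccccc1Nc1nc(SCc2ccc(C(F)(F)F)cc2)nc2ccccc12` was run in a functional assay on MCF7 cells (Homo sapiens) for cytotoxicity, read by MTT assay, with a stated time of 72 h; on this read-out lower numbers stand for stronger inhibition and higher numbers for weaker inhibition. In this assay compound 1 gives only a limit, > 50000 nM, so no number is known for it. Among the measured compounds shown here, compound 2 `FC(F)(F)c1ccc(CSc2nc(Nc3cccc(C(F)(F)F)c3)c3ccccc3n2)cc1` carries 3-(trifluoromethyl)phenyl in place of 2-methoxyphenyl on a nitrogen on an aromatic ring, and in this assay compound 2 gives 15300 nM, the only number among the two values shown. For the measured compounds named here, the step of an at least 3.2-fold lower number from compound 1 to compound 2 (0.51 log units; beyond the scatter) is the sole measured step, and it rests on (the limit of > 50000 nM in this assay, at which 1 of the 2 values shown sits).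

Compound 3 `FC(F)(F)c1ccc(CSc2nc(Nc3cccc(Cl)c3)c3ccccc3n2)cc1` differs from compound 2 by chloro in place of trifluoromethyl on an aromatic carbon. Going by the values given here, no measured step touches this change: the one step known swaps the whole aryl group on the nitrogen, not a single substituent on it. Compound 2 therefore offers the only anchor, and it is weak. Compound 3 is expected to stay close to compound 2, with an expected step of a 1.0-fold lower number from compound 2 to compound 3 (0.01 log units; within the scatter) that lies within the scatter. The estimate for compound 3 in this assay is 15000 nM, with a range from 5000 nM to 50000 nM.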

Compound 3, half-maximal inhibitory concentration: 25100 nM
Estimate against measurement, compound 3: 1.7-fold (0.22 log units) below; the range from low to high includes it.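

In this assay, a single substituent on the aryl group on the nitrogen is now compared directly, and the step is a 1.6-fold higher number from compound 2 to compound 3 (0.21 log units; within the scatter). At this position, meta to a large group, chloro and trifluoromethyl are therefore not separated by this read-out, although chloro brings 1 heavy atom where trifluoromethyl brings 4. The comparison with the 2-methoxyphenyl compound is less firm, as the step is an at least 1.9-fold lower number from compound 1 to compound 3 (0.29 log units; that floor lies within the scatter), so compound 3 adds no step beyond the scatter to the one seen for compound 2, and both steps from compound 1 depend on a limit rather than a number: the limit of > 50000 nM in this assay, at which 1 of the 3 values shown sits.

The compounds shown leave open whether a group of another kind on the same aromatic carbon, such as an amine or a carboxylic acid, would move the number beyond the scatter, since chloro and trifluoromethyl are the only two substituents compared there. They also leave open how much of the activity depends on the rest of the molecule, as the shared core and the 4-(trifluoromethyl)benzyl group on sulfur stay the same throughout, and a longer chain in place of that link would test this.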